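Replacing the methylpiperazine on compound 1 with a chloroanilino group

The source may report more compounds than this note shows. Statements on the series, on what has been measured and on what is new or still open speak of the compounds shown alone.

Three compounds have been measured in a functional assay on the whole organism (strain Wister albino) for inhibition, with Rattus norvegicus as the target, read by paw edema, with stated times of 1 h and 2 h, at a dose of 50 mg/kg by the intraperitoneal route; a lower number here means less inhibition, a higher number more inhibition at the dose given (going by the name of the read-out):
Compound 1 `CCOC(=O)c1c(-c2ccc(Cl)cc2)cc(-c2ccccc2)nc1N1CCN(C)CC1` gives 39.6%.
Compound 2 `CCOC(=O)c1c(-c2ccc(Cl)cc2)cc(-c2ccccc2)nc1Nc1ccccc1` gives 73.9%.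
Compound 3 `CCOC(=O)c1c(-c2ccc(Cl)c(Cl)c2)cc(-c2ccccc2)nc1Nc1ccc(C)cc1` gives 62.1%.

Compound 1 stands lowest of the three numbers; compound 3 lies above it beyond the scatter, and compound 2 furthest above. Compound 4 `CCOC(=O)c1c(-c2ccc(Cl)cc2)cc(-c2ccccc2)nc1Nc1ccc(Cl)cc1` differs from compound 1 by (4-chlorophenyl)amino in place of 4-methylpiperazin-1-yl on an aromatic carbon. Among the compounds with values here, the one directly relevant step is a number 34.3 percentage points higher from compound 1 to compound 2 (beyond the scatter), where an anilino group replaced the same 4-methylpiperazin-1-yl group. Compound 3, which carries a 4-methylphenylamino group but also a 3,4-dichlorophenyl group, likewise sits well above compound 1. A large upward step is therefore expected, a number 30.4 percentage points higher from compound 1 to compound 4 (beyond the scatter). Compound 4 is estimated at 70%, in the range 55% to 85%.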

Compound 4, a percentage reported as inhibition, in the whole organism at one dose (the size of the read-out at that dose, not a potency): 40.6%
For compound 4 the middle estimate is 29.4 percentage points above the measured one; the whole stated range lies above it.
By their numbers in this assay, from the lowest: compounds 1 and 4 (each within the scatter of the next); then compound 3; then compound 2.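

In this assay, the step from the methylpiperazine to the (4-chlorophenyl)amino group is a number 1 percentage points higher from compound 1 to compound 4 (within the scatter), whereas chloro in place of hydrogen on the anilino ring gives a number 33.3 percentage points lower from compound 2 to compound 4 (beyond the scatter). An anilino group at this carbon next to the ring nitrogen therefore does not secure the higher number by itself, and one chloro on that ring removes the gain seen with compound 2. Nothing available explains this loss. On these data alone, it remains open whether a fluoro or a methoxy group in that chloro's place would behave like hydrogen or like chloro.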